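Changing the Chain End on a Shared Core

The source may hold more compounds than are shown below. What is called first, only, known or untested is meant among the compounds shown, and "the series" means these compounds.

In a functional assay (trachea) with Cavia porcellus as the target (a higher number here means a weaker inhibitor, a lower number a stronger inhibitor), compound 1 `CCCCCCCCn1nc(-c2cccnc2)c2ccccc2c1=O` gives 21900 nM, compound 2 `CC(=O)OCCn1nc(-c2cccnc2)c2ccccc2c1=O` gives 9770 nM and compound 3 `O=c1c2ccccc2c(-c2cccnc2)nn1CCSc1ccccc1` gives 9120 nM. Compound 3 sits level with compound 2 and under compound 1. Changing the chain end has moved the number little so far: the data show a 2.2-fold lower number from compound 1 to compound 2 (0.35 log units; beyond the scatter) and a 2.4-fold lower number from compound 1 to compound 3 (0.38 log units; beyond the scatter), both modest, and a 1.1-fold lower number from compound 2 to compound 3 (0.03 log units; within the scatter). Compound 4 `O=c1c2ccccc2c(-c2cccnc2)nn1CCCCSc1ncccn1` carries 2-((pyrimidin-2-yl)sulfanyl)ethyl in place of phenylsulfanyl on a saturated chain carbon, two bonds along the chain from an aromatic nitrogen. Among the compounds with values here, no measured compound carries this group, so only those small steps guide the expectation. The expected change is a 1.0-fold lower number from compound 3 to compound 4 (0.01 log units; within the scatter), nothing beyond the scatter. For compound 4 the estimate is 9000 nM, with an expected range of 3500 nM to 22000 nM.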

Compound 4, half-maximal inhibitory concentration: 6170 nM
Compound 4: middle estimate off by 1.5-fold (0.16 log units), on the high side; the measured number falls inside the stated range.
By their numbers in this assay, from the lowest: compounds 4, 3 and 2 (each within the scatter of the next); then compound 1.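

With the 2-((pyrimidin-2-yl)sulfanyl)ethyl group, this assay shows a 1.5-fold lower number from compound 3 to compound 4 (0.17 log units; within the scatter) and a 1.6-fold lower number from compound 2 to compound 4 (0.20 log units; within the scatter), so this position accepts a larger end carrying a ring with hetero atoms and the number stays level with the phenylsulfanyl and acetoxy ends. Against the plain chain, the result is a 3.5-fold lower number from compound 1 to compound 4 (0.55 log units; beyond the scatter), the widest gap in the set, though still modest. Nothing measured here explains these differences. Going by these compounds, whether an amine or a carboxylic acid at the chain end would shift the number well beyond this narrow band remains open.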